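Swapping a Nitro Group for Trifluoromethoxy on Compound 1

The source may report more compounds than this note shows. Statements on the series, on what has been measured and on what is new or still open speak of the compounds shown alone.

Three compounds have been measured so far:

compound 1, `COc1ccc2cc(C(C)c3nnc4n3N=C(c3ccc([N+](=O)[O-])cc3)CS4)ccc2c1`: 14700 nM
compound 2, `CC(c1ccc(-c2ccccc2)c(F)c1)c1n[nH]c(=S)n1N`: 43100 nM
compound 3, `COc1ccc(C2=Nn3c(nnc3C(C)c3ccc(CC(C)C)cc3)SC2)cc1`: 3700 nM

These numbers come from a functional assay on Huh-7 cells (Homo sapiens) for inhibition, read by sulforhodamine B assay, with a stated time of 72 h; a lower number here means a stronger inhibitor, a higher number a weaker inhibitor. Among the three, compound 1 gives the second highest number: compound 2 sits higher, beyond the usual scatter, and compound 3 sits lower, also beyond the scatter. Compound 1 therefore stands in the middle of a spread in which each neighbour is clearly separated from it.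

Compound 4, `COc1ccc2cc(C(C)c3nnc4n3N=C(c3ccc(OC(F)(F)F)cc3)CS4)ccc2c1`, has not yet been measured. It keeps the whole framework of compound 1 and differs only at one aromatic carbon: trifluoromethoxy in place of nitro on an aromatic carbon. Among the measured compounds shown here, no measured pair shows this same exchange, so there is nothing among the known values to set its size. The expectation is a step that stays close to the scatter, leaning a little toward a lower number, since only the group at the far end of the ring is replaced and the rest of compound 1 remains intact.

Compound 4 is estimated at 10000 nM, with a plausible range from 3500 nM to 30000 nM. The step this estimate implies is a 1.5-fold lower number from compound 1 to compound 4 (0.17 log units; within the scatter).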

Compound 4, half-maximal inhibitory concentration: 16000 nM
The estimate for compound 4 lay 1.6-fold (0.20 log units) below the measured number; low and high end bracket the measured number.
By their numbers in this assay, from the lowest: compound 3; then compounds 1 and 4 (each within the scatter of the next); then compound 2.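

In this assay, among the compounds shown here, the exchange of 4-nitrophenyl for 4-(trifluoromethoxy)phenyl gives a 1.1-fold higher number from compound 1 to compound 4 (0.04 log units; within the scatter), the first comparison in this set between compounds that differ in only one place, so at this aromatic carbon, para to a large group, the two groups cannot be told apart. The pair also shows that this reading holds even though the entering trifluoromethoxy group differs from the leaving nitro group in its make-up, with 5 heavy atoms and 1 hydrogen-bond acceptor against 3 heavy atoms and 2 hydrogen-bond acceptors. No measurement at hand speaks to the reason why the two compounds read alike.

Going by these compounds, it remains open whether a quite different group at this same carbon, such as an amine or a carboxylic acid, would move the number beyond the scatter from that of compound 1. On these data alone, it also remains open whether the same exchange would leave the number just as little affected on another framework, such as that of compound 3, where this pair offers no direct guide.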